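Replacing a fluoropyridine sulfonamide with a dichlorophenyl one

The compounds below may be only part of what the source reports. "The series", "measured", "known", "first", "only" and "open" are said of these compounds alone.

Compound 1 `CC1CCN(C2CCN(S(=O)(=O)c3cccnc3F)CC2)CC1` carries a 2-fluoropyridin-3-yl group on the sulfonyl sulfur of the shared core. In a functional assay on DLD-1 cells (Homo sapiens) for antiproliferative activity, read by CellTiter-Glo, with a stated time of 72 h (on this read-out higher numbers stand for weaker inhibition and lower numbers for stronger inhibition), compound 1 gives only a limit, > 5000 nM, and not a number, as recorded in the limit of > 5000 nM in this assay, at which 1 of the 3 values shown sits. Two further compounds show what a carbon-only aromatic ring on the sulfonyl sulfur can do on a related core, although both also carry other groups that compound 1 lacks. Compound 2 `Cc1cc(C)c(S(=O)(=O)N2CCC(N3CCC(Cc4ccc(F)cc4)CC3)CC2)c(C)c1` gives 18 nM in this assay, and compound 3 `C#CCOCCC1CCN(C2CCN(S(=O)(=O)c3ccccc3)CC2)CC1` gives 85 nM in this assay. Compound 4 `CC1CCN(C2CCN(S(=O)(=O)c3ccc(Cl)cc3Cl)CC2)CC1` has not yet been measured; it differs from compound 1 in a single place: 2,4-dichlorophenyl in place of 2-fluoropyridin-3-yl on a sulfonyl sulfur. Going by the values given here, no pair of measured compounds isolates exactly this exchange, so any expectation rests on compounds 2 and 3 and on the limit of compound 1. Compound 4 is expected to gain inhibition beyond the usual scatter, with an estimated step of an at least 6.2-fold lower number from compound 1 to compound 4 (0.79 log units; beyond the scatter). Compound 4 is estimated at 800 nM in this assay, within a range from 150 nM to 5000 nM.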

Compound 4, half-maximal inhibitory concentration: 1 nM
Compound 4: middle estimate off by 800-fold (2.90 log units), on the high side; measured number below the stated range.
By their numbers in this assay, from the lowest: compound 4; then compound 2; then compound 3. At a limit, above all of these: compound 1.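

In this assay, the exchange of 2-fluoropyridin-3-yl for 2,4-dichlorophenyl gives an at least 5000-fold lower number from compound 1 to compound 4 (3.69 log units; beyond the scatter). Going by these compounds alone, the rest of the structure stays the same, so this whole step belongs to the group on the sulfonyl sulfur, whereas the earlier compounds also carried other groups and could not show this. The full size of the step cannot be read because compound 1 gives only a limit and not a number: the limit of > 5000 nM in this assay, at which 1 of the 4 values shown sits.

The compounds shown do not separate the parts of this exchange: the ring nitrogen and fluorine that leave, and the two chlorines that enter, all change together. On these data alone, a single-chlorine group such as 4-chlorophenyl would help to divide the step between them, and how an amine or a carboxylic acid on this ring would fare remains open.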